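The source may hold more compounds than are shown below. What is called first, only, known or untested is meant among the compounds shown, and "the series" means these compounds.

Working notes on the series: in an ADME assay on microsomes from liver (Homo sapiens) for metabolic stability (a lower number here means that the compound disappears faster, a higher number that the compound lasts longer), compound 1 `NS(=O)(=O)CC(=O)NCCSc1nonc1/C(=N/O)Nc1ccc(F)c(C(F)F)c1` gives 2.77 h and compound 2 `O=C(NCCSc1nonc1/C(=N/O)Nc1ccc(F)c(C(F)F)c1)C1CS(=O)(=O)C1` gives 1.28 h, the lower of the two numbers measured so far. The next compound, compound 3 `N#CCC(=O)NCCSc1nonc1/C(=N/O)Nc1ccc(F)c(C(F)F)c1`, differs from compound 2 by a group of 3 heavy atoms (2 carbon, 1 nitrogen; no ring) in place of a group of 6 heavy atoms (3 carbon, 2 oxygen, 1 sulfur; one four-membered non-aromatic ring with 1 hetero atom), on a carbonyl carbon. Cyanomethyl enters on a carbonyl carbon whose other neighbour is an amide-type nitrogen, and the four-membered non-aromatic ring leaves with its group.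

For the measured compounds named here, only one measured step bears on this change: a 2.2-fold lower number from compound 1 to compound 2 (0.34 log units; beyond the scatter). That step also changes the group on the carbonyl carbon, and it is modest. In it, a group with no ring gives way to one with a four-membered non-aromatic ring. Compound 3 returns to a group with no ring, as in compound 1 at 2.77 h, but cyanomethyl is a different and smaller group, so this is weak guidance from a single pair. A partial recovery in this assay is therefore expected, not a full return. The expected step is a 1.5-fold higher number from compound 2 to compound 3 (0.17 log units; within the scatter), a modest upward move that may not clear the scatter. For compound 3 the estimated half-life is 1.9 h, with an expected range of 0.9 h to 4 h.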

Compound 3, half-life: 2.77 h
The estimate for compound 3 lay 1.5-fold (0.16 log units) below the measured number, and the stated range covers the measured number.
By their numbers in this assay, from the lowest: compound 2; then compounds 1 and 3 (each within the scatter of the next).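

In this assay the new result gives a 2.2-fold higher number from compound 2 to compound 3 (0.34 log units; beyond the scatter), which matches in size the earlier 2.2-fold lower number from compound 1 to compound 2 (0.34 log units; beyond the scatter), so compound 2 now holds the lower number against both neighbours that differ from it on the carbonyl carbon. The second new comparison gives no change at the digits printed from compound 1 to compound 3 (within the scatter), with cyano in place of sulfamoyl on a saturated chain carbon bound to a carbonyl carbon, so two quite different ring-free groups cannot be told apart at this position. For the compounds shown here, of the three groups compared, only the one with the four-membered non-aromatic ring stands apart, though this is a pattern from three compounds and none of them goes against it; no measurement offered here accounts for that difference.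

The compounds shown leave open whether the lower number goes with the four-membered ring as such or with the sulfur and oxygen atoms it carries, a question that a plain cyclobutyl group or an oxetane ring on the carbonyl carbon would address. They also leave open how far the ring-free result extends, for example to a longer chain ending in nitrile or to a chain ending in an amine or a carboxylic acid.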